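From isobutyl to hexyloxy: what to expect

The source may hold more compounds than are shown below. What is called first, only, known or untested is meant among the compounds shown, and "the series" means these compounds.

Values in a functional assay on M21 cells (Homo sapiens) for antiproliferative activity, read by sulforhodamine B assay, with a stated time of 48 h; a higher number here means a weaker inhibitor, a lower number a stronger inhibitor:
Compound 1 `Cc1ccc(NS(=O)(=O)c2ccc(N3CCNC3=O)cc2)cc1`: 260 nM
Compound 2 `CC(C)Cc1ccc(NS(=O)(=O)c2ccc(N3CCNC3=O)cc2)cc1`: > 1000 nM (a limit)

Compound 2 stands at the limit of > 1000 nM in this assay, at which 1 of the 2 values shown sits. For compound 2 the reading of > 1000 nM is a limit and not a number. Compound 3 `CCCCCCOc1ccc(NS(=O)(=O)c2ccc(N3CCNC3=O)cc2)cc1` carries hexyloxy in place of isobutyl on an aromatic carbon, para to a large group: hexyloxy in place of isobutyl on an aromatic carbon. Going by the values given here, the one measured step that bears on this is an at least 3.8-fold higher number from compound 1 to compound 2 (0.58 log units; beyond the scatter), with isopropyl in place of hydrogen on a saturated chain carbon bound to an aromatic carbon. On that step alone, a modest further rise in this assay is expected for compound 3, and the result may again be only a limit. The estimated change is a step that the limit leaves unreadable from compound 2 to compound 3. For compound 3 the estimate is 2500 nM, with an expected range of 800 nM to 10000 nM.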

Compound 3, half-maximal inhibitory concentration: > 1000 nM
Compound 3 gave a limit, no number (the forecaster's own chance of this, stated with the estimate: 60%); the middle value is on the limit's open side.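

Measured in this assay hexyloxy in place of methyl on the aromatic carbon, para to a large group, gives an at least 3.8-fold higher number from compound 1 to compound 3 (0.58 log units; beyond the scatter), so a chain joined through oxygen falls behind compound 1 just as isobutyl does. Compound 3 reads > 1000 nM and that is a limit, not a number. The step between compound 2 and compound 3 cannot be read, and isobutyl and hexyloxy now share one ceiling: the limit of > 1000 nM in this assay, at which 2 of the 3 values shown sit.

On these data alone, how far compound 2 and compound 3 lie past that limit stays open, so the two groups cannot be ranked against each other. Also open, as far as these compounds go, is whether a short group such as ethyl or methoxy, or an amine, at this position would hold the value of compound 1 or improve on it.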